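The source may report more compounds than this note shows. Statements on the series, on what has been measured and on what is new or still open speak of the compounds shown alone.

Working notes on the sulfonamide series. Compound 1 `Cc1cccc(C)c1S(=O)(=O)NC[C@@H](O)CN1CCC[C@@]2(CCN(c3ncnc(N)c3C3CC3)C2)C1` gives 900 nM in an assay on LNCaP cells for inhibition of RAC-alpha serine/threonine-protein kinase (Homo sapiens); a higher number here means a weaker inhibitor, a lower number a stronger inhibitor. Within the data shown here, compound 2 `Nc1ncnc(N2CC[C@@]3(CCCN(C[C@H](O)CNS(=O)(=O)c4ccccc4Br)C3)C2)c1C1CC1` gives 2000 nM in this assay; the only change between the two is the aryl on the sulfonyl sulfur, and the step of a 2.2-fold higher number from compound 1 to compound 2 (0.35 log units; beyond the scatter) is the one step measured so far. On these two numbers compound 2 stands highest, with compound 1 the nearest and lower.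

Compound 3 `Cc1cc(F)ccc1S(=O)(=O)NC[C@@H](O)CN1CCC[C@@]2(CCN(c3ncnc(N)c3C3CC3)C2)C1` is still to be measured in this assay. It differs from compound 2 in one place: 4-fluoro-2-methylphenyl in place of 2-bromophenyl on a sulfonyl sulfur. Among the measured compounds shown here, the single step that bears on this change is a 2.2-fold higher number from compound 1 to compound 2 (0.35 log units; beyond the scatter), a modest one, and it shows that a methyl-bearing aryl on the sulfonyl sulfur gave the lower number. Compound 3 again carries a methyl on that aryl, so a modest move back toward the number of compound 1 is expected, a 1.7-fold lower number from compound 2 to compound 3 (0.22 log units; within the scatter), with no firm evidence for a larger effect. Compound 3 is therefore estimated at 1200 nM, within a range of 500 nM to 2800 nM.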

Compound 3, half-maximal inhibitory concentration: 2200 nM
For compound 3 the middle estimate is 1.8-fold (0.26 log units) below the measured one; the measured number falls inside the stated range.
By their numbers in this assay, from the lowest: compound 1; then compounds 2 and 3 (each within the scatter of the next).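

In this assay, 4-fluoro-2-methylphenyl in place of 2-bromophenyl on the sulfonyl sulfur gives a 1.1-fold higher number from compound 2 to compound 3 (0.04 log units; within the scatter) and so does not separate these two aryl groups, which shows that a single methyl on the aryl is not enough to bring the number back to that of compound 1. 4-Fluoro-2-methylphenyl in place of 2,6-dimethylphenyl gives a 2.4-fold higher number from compound 1 to compound 3 (0.39 log units; beyond the scatter) as the second step beyond the scatter from compound 1, leaving its 2,6-dimethylphenyl as the only aryl of the three set apart from the others. Nothing measured here accounts for these numbers.

As far as these compounds go, it remains open how an unsubstituted phenyl, a pyridine ring or a small alkyl group such as methyl on the sulfonyl sulfur would compare with the 2,6-dimethylphenyl of compound 1. From the compounds shown here alone, it also remains open whether the lower number of compound 1 depends on its second methyl group or on the absence of fluorine and bromine.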